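Amide aryl swap on a sulfonate-linked P2X7 antagonist

The source may report more compounds than this note shows. Statements on the series, on what has been measured and on what is new or still open speak of the compounds shown alone.

Measured compounds:
compound 1 `O=C(Oc1ccc(-c2cncn2C2CCN(C(=O)c3ccc(Cl)c(C(F)(F)F)c3)CC2)cc1)c1ccccc1`, > 10000 nM
compound 2 `COc1ccc(C(=O)N2CCC(n3cncc3-c3ccc(OS(=O)(=O)c4cccc5cnccc45)cc3)CC2)cc1OC`, 259 nM

In an assay on HEK293 cells for antagonist activity at P2X purinoceptor 7 (Homo sapiens), read by fluorescence, with a stated time of 2 h (on this read-out lower numbers stand for stronger inhibition and higher numbers for weaker inhibition), compound 1 returns only a limit, > 10000 nM, which is the limit described in the limit of > 10000 nM in this assay, at which 1 of the 2 values shown sits. Compound 2, with structure `COc1ccc(C(=O)N2CCC(n3cncc3-c3ccc(OS(=O)(=O)c4cccc5cnccc45)cc3)CC2)cc1OC`, gives 259 nM, the only true number shown here. Compound 3, `O=C(c1ccc([N+](=O)[O-])cc1)N1CCC(n2cncc2-c2ccc(OS(=O)(=O)c3cccc4cnccc34)cc2)CC1`, has not been measured; it differs from compound 2 by 4-nitrophenyl in place of 3,4-dimethoxyphenyl on a carbonyl carbon. Among the measured compounds shown here, no measured step covers this change, so the expectation for compound 3 is a step of a 1.5-fold higher number from compound 2 to compound 3 (0.19 log units; within the scatter) that stays near the scatter in this assay. Compound 3 is estimated at 400 nM, within 120 nM to 1500 nM.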

Compound 3, half-maximal inhibitory concentration: 1.49 nM
Estimate against measurement, compound 3: 270-fold (2.43 log units) above, outside the stated range (below it).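

In this assay, the group on the amide carbonyl proves to be a sensitive position: 4-nitrophenyl in place of 3,4-dimethoxyphenyl on a carbonyl carbon gives a 170-fold lower number from compound 2 to compound 3 (2.24 log units; beyond the scatter). This first measured step shows that this single change, with the rest of the molecule held fixed, can move the number far beyond the scatter. Nothing measured here accounts for the size of this step. Going by these compounds, it remains open whether the gain belongs to the nitro group or to the loss of the methoxy groups, and whether a nitrile or an amine on that ring would keep it.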